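Isobutyl amide weighed against two values at the limit

The source may hold more compounds than are shown below. What is called first, only, known or untested is meant among the compounds shown, and "the series" means these compounds.

Compound 1 `C=CC1=C(C(=O)Nc2ccccc2)C(c2ccc(Cl)c(Cl)c2)OC1`: in a functional assay on HeLa cells (Homo sapiens) for cytotoxicity, read by MTT assay, with a stated time of 24 h (a lower number here means a stronger inhibitor, a higher number a weaker inhibitor), compound 1 gives > 100000 nM, a limit of the assay.
Compound 2 `C=CC1=C(C(=O)Nc2ccccc2)C(c2ccc(F)cc2)OC1`: in this assay compound 2 gives > 100000 nM, also a limit of the assay.

Compound 1 stands at the limit of the assay and not at a number. Compound 2 does the same, so the two measured compounds together make up (the limit of > 100000 nM in this assay, at which 2 of the 2 values shown sit). Among the compounds with values here, the one measured step, a step that the two limits leave unreadable from compound 1 to compound 2, therefore has no readable size or direction. Compound 3 `C=CC1=C(C(=O)NCC(C)C)C(c2ccc(Cl)c(Cl)c2)OC1` differs from compound 1 by isobutyl in place of phenyl on an amide-type nitrogen. Within the data shown here, no measured step touches the amide nitrogen, and the step that exists concerns the aryl group and is not readable, so nothing in the data supports a shift beyond the scatter in either direction. Compound 3 is thus expected to remain at the limit, with an estimated step that the limit leaves unreadable from compound 1 to compound 3. The estimate for compound 3 is 150000 nM, with a range from 50000 nM to 500000 nM.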

Compound 3, half-maximal inhibitory concentration: 60100 nM
Compound 3: the middle estimate sits 2.5-fold (0.40 log units) above what was measured; low and high end bracket the measured number.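

Compound 3 is the only compound shown that gives a number rather than a limit in this assay, so the amide-type nitrogen is a place where a change can bring the read-out into measurable range. Isobutyl in place of phenyl gives an at least 1.6-fold lower number from compound 1 to compound 3 (0.22 log units; that floor lies within the scatter); this is a floor and not a measured size, so the data show a number where there was a limit, but no shift established beyond the scatter. The limit still holds most of the series: the limit of > 100000 nM in this assay, at which 2 of the 3 values shown sit.

On these data alone, it remains open whether the same change on the amide-type nitrogen would give a number with the 4-fluorophenyl group of compound 2. Also open, as far as these compounds go, is how the value would respond to a longer alkyl chain, a cyclohexyl group or a benzyl group on that nitrogen.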